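A swap on the carbonyl carbon, still unmeasured

This account rests on a few compounds, and the source may have more. Where it says the series, first, only, none or still open, it means among the compounds named here.

Compound 1 `CNC(=O)c1cc(Oc2ccc3c(C)c(C(=O)OC)sc3c2)ccn1` – 10800 nM
Compound 2 `CNC(=O)c1cc(Oc2ccc3c(C)c(C(=O)OCc4ccccc4)sc3c2)ccn1` – 18800 nM

In an ADME assay on H1-HeLa cells (Homo sapiens) for cytotoxicity, read by MTT assay, with a stated time of 3 days (on this read-out higher numbers stand for lower toxicity in this test and lower numbers for higher toxicity in this test), compound 2 gives 18800 nM and compound 1 gives 10800 nM on the same read-out, so the two lie within the scatter of each other and cannot be ranked. Within the data shown here, the only measured step is a 1.7-fold higher number from compound 1 to compound 2 (0.24 log units; within the scatter) and it places phenyl in place of hydrogen on a saturated chain carbon bound to an oxygen. Compound 3 `CNC(=O)c1cc(Oc2ccc3c(C)c(C(=O)N(C)C)sc3c2)ccn1` has not yet been measured. Its difference from compound 2 is dimethylamino in place of benzyloxy on a carbonyl carbon with dimethylamino in place of benzyloxy on a carbonyl carbon. Among the measured compounds shown here, no measured step covers this exchange, so the one step available bears on it only loosely. That step stayed within the scatter, and no step beyond the scatter is expected here in either direction, although the range is kept wide. The expected change is a 1.3-fold lower number from compound 2 to compound 3 (0.13 log units; within the scatter) by estimate alone. Compound 3 is expected at 14000 nM with 6000 nM to 35000 nM as the estimated range.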

Compound 3, half-maximal cytotoxic concentration: 42500 nM
Beside the measured number, compound 3's estimate is 3.0-fold (0.48 log units) below it; the whole stated range lies below it.
By their numbers in this assay, from the lowest: compounds 1 and 2 (each within the scatter of the next); then compound 3.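

Among these compounds, at the carbonyl carbon, the exchange of the ester group for dimethylamino gives a 2.3-fold higher number from compound 2 to compound 3 (0.35 log units; beyond the scatter) and a 3.9-fold higher number from compound 1 to compound 3 (0.59 log units; beyond the scatter) in this assay and so moves the number beyond the scatter, which the one earlier step at this part of the molecule, on the chain of the ester, did not do. Both steps are modest and run the same way, which puts compound 3 at the highest number of the three and thus at the lower toxicity in this test. Since compound 1 and compound 2 cannot be ranked against each other, the ring of the benzyloxy group is not what this rise depends on: the step appears whether dimethylamino replaces benzyloxy or methoxy.

Going by these compounds, whether the rise goes with the amide as such or with its two methyl groups stays open, as does the reading for a carboxylic acid, a primary amide or a morpholine amide on the same carbonyl carbon. Nothing available on these compounds accounts for the rise.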